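Methyl in place of isopropyl on the aryl ring

The source may report more compounds than this note shows. Statements on the series, on what has been measured and on what is new or still open speak of the compounds shown alone.

The measured compounds:
compound 1 `O=C1C=CC(OCC(F)(F)F)N1c1ccc(C(F)(F)F)cc1` gives 2300 nM in a functional assay on MDA-MB-231 cells (Homo sapiens) for inhibition; on this read-out lower numbers stand for stronger inhibition and higher numbers for weaker inhibition;
compound 2 `CC(C)c1ccc(N2C(=O)C=CC2OCC(F)(F)F)cc1` gives 6640 nM in this assay.

Among the compounds with values here, compound 2 stands at the higher of the two numbers in this assay: the step of a 2.9-fold higher number from compound 1 to compound 2 (0.46 log units; beyond the scatter) lies beyond the usual scatter and is the only measured step so far. It tells what happens when isopropyl replaces trifluoromethyl on an aromatic carbon.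

Compound 3 `Cc1ccc(N2C(=O)C=CC2OCC(F)(F)F)cc1` is not yet measured. The change from compound 2 to compound 3 is methyl in place of isopropyl on an aromatic carbon. Within the data shown here, no measured step covers this exact exchange; the one step known, from compound 1 to compound 2, concerns a different group at the same position, and its size was modest. It shows that substituents at this position move the number in this assay by a modest amount, so a change of similar size, in either direction, is the reasonable expectation here, with no strong reason to favour one direction.

The estimate for compound 3 in this assay is therefore 4500 nM, with a range from 1500 nM to 13000 nM, which as a step means a 1.5-fold lower number from compound 2 to compound 3 (0.17 log units; within the scatter) expected from compound 2.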

Compound 3, half-maximal inhibitory concentration: 15800 nM
Beside the measured number, compound 3's estimate is 3.5-fold (0.55 log units) below it, outside the stated range (above it).
By their numbers in this assay, from the lowest: compound 1; then compound 2; then compound 3.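

In this assay, the exchange of isopropyl for methyl on this aromatic carbon, para to a large group, is not neutral: there is a 2.4-fold higher number from compound 2 to compound 3 (0.38 log units; beyond the scatter), so removing carbons from the alkyl group here goes with a higher number. Taken with a 6.9-fold higher number from compound 1 to compound 3 (0.84 log units; beyond the scatter), this widens the range seen at this position beyond what the single earlier step showed, and it orders the three groups, with trifluoromethyl giving the lowest number, isopropyl the middle one and methyl the highest. Nothing available here accounts for this order.

Going by these compounds, whether a chlorine atom, a methoxy group or a nitrile at this position would fall within this order remains open, as does whether a longer chain such as tert-butyl would carry the number lower than isopropyl does. The trifluoroethoxy group stays the same in all three compounds, so it is also unknown how an amine in its place would change the number, or whether the order of the aryl groups would then hold.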